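Compound 3 to compound 4: a shorter chain

This account rests on a few compounds, and the source may have more. Where it says the series, first, only, none or still open, it means among the compounds named here.

Measured in an ADME assay on MCF7-DOX cells (Homo sapiens) for cytotoxicity, read by MTT assay, with a stated time of 48 h; on this read-out higher numbers stand for weaker inhibition and lower numbers for stronger inhibition:
- compound 1 `COc1cc(O)c(C(=O)/C=C/c2cccc(N3CCNCC3)c2)c(OC)c1`: 99200 nM
- compound 2 `CCCCCc1c(OC)cc(OC)c(C(=O)/C=C/c2cccc(N3CCNCC3)c2)c1O`: > 100000 nM (a limit of the assay, not a number)
- compound 3 `COc1cc(OC)c(C(=O)/C=C/c2cccc(N3CCNCC3)c2)c(O)c1CC=C(C)C`: 99900 nM

For the measured compounds named here, compound 3 gives 99900 nM and lies within the scatter of compound 1, the only other compound with a number. Compound 2 is reported only as a limit, (the limit of > 100000 nM in this assay, at which 1 of the 3 values shown sits).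

Compound 4 `COc1cc(OC)c(C(=O)/C=C/c2cccc(N3CCNCC3)c2)c(O)c1C` differs from compound 3 by hydrogen in place of 2-methylprop-1-en-1-yl on a saturated chain carbon bound to an aromatic carbon. Cut one bond further out, this reads 3-methylbut-2-en-1-yl to methyl.

The measured step that bears most directly on this is a 1.0-fold higher number from compound 1 to compound 3 (0.00 log units; within the scatter), where 3-methylbut-2-en-1-yl replaces hydrogen on an aromatic carbon. Compound 4 carries methyl on that same aromatic carbon. The other two steps, a number no lower from compound 1 to compound 2 (the limit leaves the size open) and a number no higher from compound 2 to compound 3 (the limit leaves the size open), give no size.

With only the within-scatter step from compound 1 to compound 3 as a guide, no step beyond the scatter is expected in this assay. The expected step is a 1.1-fold lower number from compound 3 to compound 4 (0.02 log units; within the scatter). The estimate for compound 4 is 95000 nM, with an expected range of 50000 nM to 150000 nM.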

Compound 4, half-maximal inhibitory concentration: 98700 nM
The estimate for compound 4 lay 1.0-fold (0.02 log units) below the measured number, within the range that was stated.
By their numbers in this assay, from the lowest: compounds 4, 1 and 3 (each within the scatter of the next). At a limit, above all of these: compound 2.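

In this assay the aromatic carbon now carries a third substituent, and methyl reads no differently from hydrogen, with a 1.0-fold lower number from compound 1 to compound 4 (0.00 log units; within the scatter) and with a 1.0-fold lower number from compound 3 to compound 4 (0.01 log units; within the scatter) alongside it. The earlier numbers covered only hydrogen and 3-methylbut-2-en-1-yl at this carbon, and methyl now fills in a shorter chain, with all three values within the scatter of each other and no trend with chain length among them. Compound 2, with pentyl on the same carbon, is reported only as a limit and not as a number, and an at least 1.0-fold lower number from compound 2 to compound 4 (0.00 log units; that floor lies within the scatter) gives no more than a floor: the limit of > 100000 nM in this assay, at which 1 of the 4 values shown sits.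

Open, from the compounds shown here alone, is whether an amine or a carboxylic acid on that aromatic carbon, in place of these carbon chains, would give a step beyond the scatter, as every step with a readable size here lies within it. Open too, going by these compounds, is whether hydrogen, methyl and 3-methylbut-2-en-1-yl would still read alike on this carbon in a different assay.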